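Replacing the Aminophenyl on the Pyrrole Nitrogen

This account rests on a few compounds, and the source may have more. Where it says the series, first, only, none or still open, it means among the compounds named here.

Measured compounds:
compound 1 `COc1cc(C(=O)c2cn(-c3ccccc3N)cc2-c2ccccc2)cc(OC)c1OC`, 3800 nM
compound 2 `COc1cc(C(=O)c2cn(-c3ccc(Cl)cc3)cc2-c2ccccc2)cc(OC)c1OC`, 140 nM

In a functional assay on MCF7 cells (Homo sapiens) for cytotoxicity, read by MTT assay, with a stated time of 96 h (on this read-out higher numbers stand for weaker inhibition and lower numbers for stronger inhibition), compound 1 gives the highest of the two numbers; its nearest neighbour is compound 2, and the step of a 27-fold lower number from compound 1 to compound 2 (1.43 log units; beyond the scatter) is large and beyond the scatter. Compound 3 `COc1cc(C(=O)c2cn(-c3cc(OC)c(OC)c(OC)c3)cc2-c2ccccc2)cc(OC)c1OC` has not yet been measured in this assay. It differs from compound 1 by 3,4,5-trimethoxyphenyl in place of 2-aminophenyl on an aromatic nitrogen. Among the compounds with values here, the only measured step that bears on this change is the one from compound 1 to compound 2, where a different aryl group also took the place of 2-aminophenyl on the aromatic nitrogen and the number fell sharply. On that basis a step downward beyond the scatter is expected from compound 1 to compound 3, a 9.5-fold lower number from compound 1 to compound 3 (0.98 log units; beyond the scatter), though the new group is not the same as in compound 2, so the size is uncertain. Compound 3 is therefore estimated at 400 nM, in the range 80 nM to 2500 nM.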

Compound 3, half-maximal inhibitory concentration: > 5000 nM
Compound 3: no number, only a limit; the forecaster's own chance of this, stated with the estimate: 5%; middle value at least 12-fold (1.09 log units) away from the limit.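

The reading for compound 3 in this assay is a limit of the assay and not a number: the limit of > 5000 nM in this assay, at which 1 of the 3 values shown sits. The large fall in the number seen earlier therefore does not follow from every aryl group replacing 2-aminophenyl on the aromatic nitrogen, as 3,4,5-trimethoxyphenyl in place of 4-chlorophenyl gives an at least 35-fold higher number from compound 2 to compound 3 (1.55 log units; beyond the scatter). Against the starting compound the reading is an at least 1.3-fold higher number from compound 1 to compound 3 (0.11 log units; that floor lies within the scatter), so the true distance between 3,4,5-trimethoxyphenyl and 2-aminophenyl at this position stays unknown.

The compounds shown leave open whether the low number of compound 2 goes with the chlorine itself or with the phenyl ring that carries it. They also leave open how a plain phenyl or a 4-methoxyphenyl on the aromatic nitrogen would read in this assay.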